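Swapping the triazole substituent: does cyclopropyl change anything?

The source may hold more compounds than are shown below. What is called first, only, known or untested is meant among the compounds shown, and "the series" means these compounds.

Three compounds sharing one core have been measured in an ADME assay on SK-OV-3 cells (Homo sapiens) for cytotoxicity, read by sulforhodamine B assay, with a stated time of 48 h, tested at 10 uM; on this read-out higher numbers stand for more inhibition at the one concentration tested (going by the name of the read-out) and lower numbers for less inhibition:

compound 1, `CCCCCCCc1cn(C(c2ccccc2)c2cc3cc(Br)ccc3nc2OC)nn1`, gives 10.5%
compound 2, `CCOC(=O)c1cn(C(c2ccccc2)c2cc3cc(Br)ccc3nc2OC)nn1`, gives 2.01%
compound 3, `COc1nc2ccc(Br)cc2cc1C(c1ccccc1)n1cc(CO)nn1`, gives 3.23%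

Compound 2 gives the smallest of the three numbers, yet both gaps to its neighbours lie within the usual scatter: a number 8.5 percentage points lower from compound 1 to compound 2 (within the scatter) and a number 1.2 percentage points higher from compound 2 to compound 3 (within the scatter). The step considered here is from compound 2 to compound 4, `COc1nc2ccc(Br)cc2cc1C(c1ccccc1)n1cc(C2CC2)nn1`. The change is cyclopropyl in place of ethoxycarbonyl on an aromatic carbon. For the measured compounds named here, two measured steps bear on this, since each alters the group on the same aromatic carbon of the five-membered ring: the step from heptyl to ethoxycarbonyl, a number 8.5 percentage points lower from compound 1 to compound 2 (within the scatter), and the step from ethoxycarbonyl to hydroxymethyl, a number 1.2 percentage points higher from compound 2 to compound 3 (within the scatter). Neither moved the number beyond the scatter, and the third step, a number 7.3 percentage points lower from compound 1 to compound 3 (within the scatter), was also within it. No change at this position has so far produced a real shift in this assay, so for the cyclopropyl group no step beyond the scatter is expected either; the expected step is a number 3 percentage points higher from compound 2 to compound 4 (within the scatter). Compound 4 is therefore estimated at 5%, within the range -5% to 16%.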

Compound 4, a percentage reported as inhibition, at one concentration (the size of the read-out at that concentration, not a potency): 3.52%
Compound 4: middle estimate off by 1.5 percentage points, on the high side; low and high end bracket the measured number.
By their numbers in this assay, from the lowest: compounds 2, 3, 4 and 1 (each within the scatter of the next).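

Cyclopropyl adds a small carbon-only ring to the groups tried on this aromatic carbon, and in this assay it gives no step beyond the scatter against any of them: a number 1.5 percentage points higher from compound 2 to compound 4 (within the scatter) against ethoxycarbonyl, a number 0.3 percentage points higher from compound 3 to compound 4 (within the scatter) against hydroxymethyl, and a number 7 percentage points lower from compound 1 to compound 4 (within the scatter) against heptyl. Even the exchange of ethoxycarbonyl, which has a double bond outside the aromatic rings and hydrogen-bond acceptors, for a ring with neither leaves the two compounds within the scatter of each other. No measurement here gives a cause for these results.

As far as these compounds go, whether an amine or a carboxylic acid on this carbon would give a step beyond the scatter remains open. Also open, from the compounds shown here alone, is what replacing the bromine on the shared core would do in this assay at this concentration.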